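The compounds below may be only part of what the source reports. "The series", "measured", "known", "first", "only" and "open" are said of these compounds alone.

Working notes on the series in a functional assay on SR cells (Homo sapiens) for inhibition, read by sulforhodamine B assay, with a stated time of 48 h; a lower number here means a stronger inhibitor of growth, a higher number a weaker inhibitor of growth.

Compound 1 `O=C(Nc1cccc(-n2cc(-c3ccncc3)c(-c3ccc(Cl)c(O)c3)n2)c1)Nc1ccc(Cl)c(Cl)c1` gives 15000 nM in this assay, the higher of the two numbers in hand. Compound 3 `O=C(Nc1cccc(-n2cc(-c3ccncc3)c(-c3ccc(Cl)c(O)c3)n2)c1)Nc1cc(C(F)(F)F)cc(C(F)(F)F)c1` gives 3660 nM in this assay, a lower figure that sits beyond the usual scatter from compound 1. Within the data shown here, compound 2 `COc1cc(-c2nn(-c3cccc(NC(=O)c4ccc(Cl)c(C(F)(F)F)c4)c3)cc2-c2ccncc2)ccc1Cl` reaches only a limit of the assay, > 32500 nM in this assay; the limit of > 32500 nM in this assay, at which 1 of the 3 values shown sits, records it as the one value of this kind among the three.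

Compound 4 `O=C(Nc1cccc(-n2cc(-c3ccncc3)c(-c3ccc(Cl)c(O)c3)n2)c1)Nc1ccc(Cl)c(C(F)(F)F)c1` is the next member to be measured. It is compound 1 with one change, (trifluoromethyl in place of chloro on an aromatic carbon). Among the measured compounds shown here, no measured pair carries exactly this change. Since the bis-trifluoromethyl compound 3 lies below compound 1, a moderate drop in number is expected for compound 4, an estimated step of a 1.9-fold lower number from compound 1 to compound 4 (0.27 log units; within the scatter). Compound 4 is estimated at 8000 nM in this assay, with a range from 3000 nM to 25000 nM.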

Compound 4, concentration for total growth inhibition: 2520 nM
Beside the measured number, compound 4's estimate is 3.2-fold (0.50 log units) above it; measured number outside the range, below it.
By their numbers in this assay, from the lowest: compounds 4 and 3 (each within the scatter of the next); then compound 1. At a limit, above all of these: compound 2.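

At this position, with the chloro group ortho to it kept, trifluoromethyl in place of chloro gives a 6.0-fold lower number from compound 1 to compound 4 (0.77 log units; beyond the scatter) in this assay. Among these compounds, compounds 1, 2 and 3 hold no pair that differs in one place, so this is the only direct reading of this position and this change. Nothing measured in hand accounts for the step.

As far as these compounds go, whether a nitrile or an amine in place of chloro on this aromatic carbon would give a step of similar size stays open. So does whether the same change holds on a different core.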